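A further methoxy on compound 3

A few compounds are considered here, and "the series" means these few. Any claim that something is new, unique, unknown or untested is made for them only; others in the source may bear on it.

Values in a functional assay on A2780 cells (Homo sapiens) for inhibition, read by sulforhodamine B assay (on this read-out higher numbers stand for weaker inhibition of growth and lower numbers for stronger inhibition of growth), follow
Compound 1 `Cc1ccc2[nH]c(-c3ccc(-c4ccc(-c5ccc(N(C)C)cc5)cc4)cc3)nc2c1` gives 2210 nM
Compound 2 `Cc1ccc2[nH]c(-c3ccc(-c4ccc(-c5cccc(Cl)c5)cc4)cc3)nc2c1` gives 2800 nM
Compound 3 `COc1ccc(-c2ccc(-c3ccc(-c4nc5cc(C)ccc5[nH]4)cc3)cc2)cc1OC` gives 2130 nM

Compound 3 stands level with the other two: a 1.0-fold lower number from compound 1 to compound 3 (0.02 log units; within the scatter) and a 1.3-fold lower number from compound 2 to compound 3 (0.12 log units; within the scatter) are both within the scatter. Compound 4 `COc1cc(-c2ccc(-c3ccc(-c4nc5cc(C)ccc5[nH]4)cc3)cc2)cc(OC)c1OC` differs from compound 3 in one place, with methoxy in place of hydrogen on an aromatic carbon and the new group ortho to a methoxy group, meta to a large group and meta to a methoxy group.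

Among the measured compounds shown here, no measured step makes this exact change. The closest evidence is the swapping of whole substituted phenyl groups on an aromatic carbon, and even a 1.3-fold higher number from compound 1 to compound 2 (0.10 log units; within the scatter) stays within the scatter, as do the two steps already named. Three compounds are thin evidence, yet nothing in them points either way, so in this assay no step beyond the scatter is expected and no direction can be named. The expected step is a 1.0-fold lower number from compound 3 to compound 4 (0.01 log units; within the scatter) and so lies within the usual scatter. For compound 4 the estimated value is 2100 nM within an expected range of 1100 nM to 4000 nM for repeat measurements.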

Compound 4, concentration for 50% growth inhibition: 190 nM
Estimate against measurement, compound 4: 11-fold (1.04 log units) above; measured number outside the range, below it.
By their numbers in this assay, from the lowest: compound 4; then compounds 3, 1 and 2 (each within the scatter of the next).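

In this assay, methoxy in place of hydrogen on an aromatic carbon, ortho to a methoxy group, meta to a large group and meta to a methoxy group, gives an 11-fold lower number from compound 3 to compound 4 (1.05 log units; beyond the scatter), a large step towards stronger inhibition of growth. Compounds 1, 2 and 3, which carry 4-(dimethylamino)phenyl, 3-chlorophenyl and 3,4-dimethoxyphenyl, lie within the scatter of one another, so they gave no sign that this part of the molecule could matter so much, yet here a group of only 2 heavy atoms, with no ring and no net charge, is enough to shift the number far beyond the scatter. No evidence at hand says why this single change has so large an effect.

On these data alone, it remains open whether the step belongs to methoxy itself or whether another small group at this position, such as hydroxy, fluorine or ethoxy, would give a similar number. As far as these compounds go, it also remains open whether the step depends on the two methoxy groups already present in compound 3, which a compound with a single methoxy at this position could begin to test.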